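The source may hold more compounds than are shown below. What is called first, only, known or untested is meant among the compounds shown, and "the series" means these compounds.

Working notes on the series.

Compound 1 `O=C(Nc1ccc(Cl)c(-c2nnc3c(Cl)cccn23)c1)c1cccc(Cl)c1` is the reference point of the set. Among the compounds with values here, in a functional assay on MCF7 cells (Homo sapiens) for antiproliferative activity, read by MTT assay, with a stated time of 72 h (on this read-out higher numbers stand for weaker inhibition and lower numbers for stronger inhibition), compound 1 gives 71900 nM, and this is the only actual number recorded so far. Compound 2 `CS(=O)(=O)c1ccc(C(=O)Nc2ccc(Cl)c(-c3nnc4c(Cl)cccn34)c2)c(Cl)c1` shares the core and the amide link. In this assay compound 2 reaches only a limit of the assay, > 100000 nM, so no number exists for it. Within the data shown here, that limit, (the limit of > 100000 nM in this assay, at which 1 of the 2 values shown sits), is where one of the two recorded values sits, which leaves compound 1 as the single compound with a measured concentration and nothing to order it against.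

Compound 3 `O=C(Nc1ccc(Cl)c(-c2nnc3c(Cl)cccn23)c1)c1cccnc1Cl` has not been measured yet. It differs from compound 1 by 2-chloropyridin-3-yl in place of 3-chlorophenyl on a carbonyl carbon. Among the measured compounds shown here, no measured pair shows the effect of such a change, so no size of step can be read off from the data. The expectation is a step from compound 1 to compound 3 of a 1.1-fold higher number from compound 1 to compound 3 (0.05 log units; within the scatter), that is, none beyond the usual scatter of this assay. Compound 3 is estimated at 80000 nM in this assay, with a range from 30000 nM to 200000 nM.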

Compound 3, half-maximal inhibitory concentration: > 100000 nM
Compound 3 ended at the assay's limit; the forecaster's own chance of this, stated with the estimate: 35%; middle value at least 1.2-fold (0.09 log units) away from the limit.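

In this assay, within the data shown here, 2-chloropyridin-3-yl in place of 3-chlorophenyl on the carbonyl carbon gives the one step that can be read so far: an at least 1.3-fold higher number from compound 1 to compound 3 (0.14 log units; that floor lies within the scatter). Compound 3 sits at a limit of the assay, > 100000 nM, which is not a number, so the step has a floor but no known upper end, and its true size may or may not go beyond the usual scatter. This change brings no lower number at this position, and the recorded values now gather at the top of the measurable range: the limit of > 100000 nM in this assay, at which 2 of the 3 values shown sit.

Among these compounds, compound 1, at 71900 nM, remains the only compound with a measured concentration, and a single pair cannot separate the effect of the ring nitrogen from that of the different place of the chlorine in the two group names. Also open, from the compounds shown here alone, is whether an unsubstituted phenyl, a phenyl carrying an amine or a carboxylic acid, or a saturated ring such as piperidine on the same carbonyl carbon would give a measurable number in this assay.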